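Three inactive analogues and a chloroacetamide replacement

The source may report more compounds than this note shows. Statements on the series, on what has been measured and on what is new or still open speak of the compounds shown alone.

Compound 1 `COc1ccccc1C(=O)Nc1nnc(SCC(=O)Nc2ccc(Br)cn2)s1`, compound 2 `COc1ccccc1C(=O)Nc1nnc(SCC(=O)Nc2ccc(Cl)cn2)s1` and compound 3 `COc1ccccc1C(=O)Nc1nnc(SCC(=O)Nc2c(C)ccnc2Cl)s1` share one core and differ only at the amide-type nitrogen or on an aromatic carbon. In a functional assay on NCI-H460 cells (Homo sapiens) for antiproliferative activity, read by MTT assay, with a stated time of 48 h (on this read-out lower numbers stand for stronger inhibition and higher numbers for weaker inhibition), compound 1 gives > 80000 nM, which is a limit of the assay. In this assay compound 2 gives > 80000 nM, again a limit. In this assay compound 3 gives > 80000 nM, also a limit. Accordingly the steps a step that the two limits leave unreadable from compound 1 to compound 2, a step that the two limits leave unreadable from compound 1 to compound 3 and a step that the two limits leave unreadable from compound 2 to compound 3 cannot be sized, and compound 3 stands together with the other two at the limit, as summarised by the limit of > 80000 nM in this assay, at which 3 of the 3 values shown sit.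

Compound 4 `Cc1ccnc(Cl)c1NC(=O)CSc1nnc(NC(=O)CCl)s1` has not yet been measured in this assay. It differs from compound 3 by chloromethyl in place of 2-methoxyphenyl on a carbonyl carbon. Within the data shown here, no measured step touches this carbonyl carbon, so the three unreadable steps give no guide to its size or direction. With every measured value a limit, the most defensible expectation is that compound 4 also returns a limit, though a change of this extent at a new position leaves room for a measurable number.

Compound 4 is therefore estimated at 80000 nM in this assay, with a range from 15000 nM to 300000 nM. The step from compound 3 to compound 4 expected on this basis is a number no higher from compound 3 to compound 4 (the limit leaves the size open), not readable against a limit.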

Compound 4, half-maximal inhibitory concentration: 59600 nM
The estimate for compound 4 lay 1.3-fold (0.13 log units) above the measured number; low and high end bracket the measured number.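

Among these compounds, the carbonyl carbon is the first position where a change gives a number rather than a limit: in this assay, compound 4 gives 59600 nM. Chloromethyl in place of 2-methoxyphenyl, which removes the aromatic ring from this position, gives an at least 1.3-fold lower number from compound 3 to compound 4 (0.12 log units; that floor lies within the scatter), so this is a floor on the step and the true size stays open. The steps among the first three compounds still cannot be read, and the series remains mostly at the limit: the limit of > 80000 nM in this assay, at which 3 of the 4 values shown sit.

As far as these compounds go, it remains open whether the readable value goes with the chloromethyl group itself or simply with the loss of 2-methoxyphenyl, a question that a plain methyl, a phenyl or an aminomethyl group on the same carbonyl carbon would address. From the compounds shown here alone, it is also open whether chloromethyl on this carbonyl carbon would give a readable value alongside 5-bromopyridin-2-yl or 5-chloropyridin-2-yl on the amide-type nitrogen, since only the 2-chloro-4-methylpyridin-3-yl group appears with it here.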